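A methoxy in place of chloro on the shared core

The source may hold more compounds than are shown below. What is called first, only, known or untested is meant among the compounds shown, and "the series" means these compounds.

Of the compounds shown here, three sharing one core have been measured in an assay on isolated protein for inhibition of complement C1r subcomponent (Homo sapiens); a lower number here means a stronger inhibitor, a higher number a weaker inhibitor. Compound 1 `O=c1oc(-c2ccccc2I)nc2ccccc12` gives 16700 nM. Compound 2 `O=c1oc(-c2ccccc2I)nc2ccc(Cl)cc12`, with chloro in place of hydrogen on an aromatic carbon, gives 7800 nM in this assay. The step of a 2.1-fold lower number from compound 1 to compound 2 (0.33 log units; beyond the scatter) is a modest gain. Compound 3 `O=c1oc(-c2ccccc2I)nc2cc(Cl)c(Cl)cc12` reaches only a limit of this assay, > 62500 nM. Going by the values given here, the step of an at least 8.0-fold higher number from compound 2 to compound 3 (0.90 log units; beyond the scatter) thus runs the other way, and compound 2 holds the lower of the two numbers known, with compound 1 as its nearest neighbour.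

Compound 4 `COc1ccc2nc(-c3ccccc3I)oc(=O)c2c1` differs from compound 2 by one change: methoxy in place of chloro on an aromatic carbon. Both measured steps concern chloro entering this ring, and none concerns methoxy, so they bound the question only loosely: a single substituent at this position helped in the step of a 2.1-fold lower number from compound 1 to compound 2 (0.33 log units; beyond the scatter), while a second one hurt in the step of an at least 8.0-fold higher number from compound 2 to compound 3 (0.90 log units; beyond the scatter). A methoxy in the same place is expected to behave somewhere between a bare ring and a chloro-bearing one, so in this assay compound 4 is expected to give about 12000 nM, within the range 5000 nM to 30000 nM. The expected step of a 1.5-fold higher number from compound 2 to compound 4 (0.19 log units; within the scatter) is therefore a small weakening, possibly within the scatter.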

Compound 4, half-maximal inhibitory concentration: > 62500 nM
Compound 4: no number, only a limit; the forecaster's own chance of this, stated with the estimate: 5%; middle value at least 5.2-fold (0.71 log units) away from the limit.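

In this assay, the only substituent seen so far to help at this position was chloro, and replacing it with methoxy gives an at least 8.0-fold higher number from compound 2 to compound 4 (0.90 log units; beyond the scatter), so the gain seen with chloro does not carry over to methoxy. Methoxy also compares unfavourably with the hydrogen of the unsubstituted compound, with an at least 3.7-fold higher number from compound 1 to compound 4 (0.57 log units; beyond the scatter), which shows that a single substituent at this position does not help as such and that the outcome depends on which group enters. Compound 4 gives only a limit and no number, and it shares that reading with compound 3: the limit of > 62500 nM in this assay, at which 2 of the 4 values shown sit.

From the compounds shown here alone, the true size of both new steps remains open, as does any ordering of compound 3 and compound 4, since each has only a limit. Nor do the compounds shown settle whether the loss is particular to methoxy or would also appear with a hydroxyl, a fluoro, an amine or a longer chain such as ethoxy at this position.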